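The source may report more compounds than this note shows. Statements on the series, on what has been measured and on what is new or still open speak of the compounds shown alone.

Measured so far in a functional assay on A549 cells (Homo sapiens) for inhibition, read by MTT assay, with a stated time of 24 h; a lower number here means a stronger inhibitor, a higher number a weaker inhibitor:

- compound 1 `CCOC(=O)C1=Cc2ccccc2OC1(OCc1cn(CC(=O)Nc2ccc(C)cc2)nn1)C(F)(F)F` gives 54300 nM
- compound 2 `CCOC(=O)C1=Cc2ccccc2OC1(OCc1cc(-c2ccc(Cl)cc2)no1)C(F)(F)F` gives 19100 nM
- compound 3 `O=C(O)C1=Cc2ccccc2OC1(OCc1cc(-c2ccc(F)cc2)no1)C(F)(F)F`: its result is a limit of the assay, not a number, > 150000 nM

Among the two numbers shown, compound 1 stands highest; the nearest is compound 2, whose number is lower by a gap that lies beyond the usual scatter. For compound 3 only a limit is known, as stated in the limit of > 150000 nM in this assay, at which 1 of the 3 values shown sits, so nothing can be said about how it orders against the others. The three compounds differ from one another in more than one place, so none of these comparisons isolates a single change.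

Compound 4 `CCOC(=O)C1=Cc2ccccc2OC1(OCc1cn(CC(=O)Nc2ccc(I)cc2Cl)nn1)C(F)(F)F` is not yet measured in this assay. It keeps the core and the ester of compound 1 and differs from it by 2-chloro-4-iodophenyl in place of 4-methylphenyl on an amide-type nitrogen. Going by the values given here, no pair of measured compounds differs in only this place, so the data give no step to read the size of this change from. In this assay the step from compound 1 to compound 4 is expected to be small, with no clear direction beyond the scatter, a 1.2-fold lower number from compound 1 to compound 4 (0.08 log units; within the scatter). Compound 4 is therefore estimated at 45000 nM in this assay, within a range from 15000 nM to 150000 nM.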

Compound 4, half-maximal inhibitory concentration: 22300 nM
Compound 4: the middle estimate sits 2.0-fold (0.30 log units) above what was measured, and the stated range covers the measured number.
By their numbers in this assay, from the lowest: compounds 2 and 4 (each within the scatter of the next); then compound 1. At a limit, above all of these: compound 3.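

In this assay, going by these compounds alone, the aryl group on the amide-type nitrogen is the first place where a single change can be read: a 2.4-fold lower number from compound 1 to compound 4 (0.39 log units; beyond the scatter). The step is modest but lies beyond the scatter, so this position does respond to 2-chloro-4-iodophenyl in place of 4-methylphenyl while the ester and the shared core stay the same. No measured property shown here bears on this step, so it stands as an observation without an explanation.

The change removes the methyl and brings in chlorine and iodine together, so the share of each halogen in the step stays unresolved, and a phenyl carrying only chlorine or only iodine on this amide would be needed to separate them. Within the data shown here, also open is how this position would respond to an amine or a carboxylic acid on the phenyl ring, or to a longer chain in place of the ((4-methylphenyl)carbamoyl)methyl link, as the series so far offers only these two aryl groups here.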